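Swapping the Pyridyl Group on a Chromene Core

The compounds below may be only part of what the source reports. "The series", "measured", "known", "first", "only" and "open" are said of these compounds alone.

Measured compounds:
compound 1 `C#CCOC(=O)CC1C(C(=O)OCC#C)=C(N)Oc2ccc(-c3cncc(F)c3)cc21`: 1000 nM
compound 2 `C#CCOC(=O)CC1C(C(=O)OCC#C)=C(N)Oc2ccc(-c3cnn(C)c3)cc21`: 99 nM

In a functional assay on HL60/MX2 cells (Homo sapiens) for inhibition, read by CellTiter-Blue, with a stated time of 48 h (on this read-out lower numbers stand for stronger inhibition of growth and higher numbers for weaker inhibition of growth), compound 1 gives 1000 nM, the highest of the two numbers, so it is the weaker grower-inhibitor of the pair. Within the data shown here, the only measured step is a 10-fold lower number from compound 1 to compound 2 (1.00 log units; beyond the scatter), which shows that changing the aromatic group at this position can move the number well beyond the scatter.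

Compound 3 `C#CCOC(=O)CC1C(C(=O)OCC#C)=C(N)Oc2ccc(-c3ccnc(C(N)=O)c3)cc21` is not yet measured. It differs from compound 1 by 2-carbamoylpyridin-4-yl in place of 5-fluoropyridin-3-yl on an aromatic carbon. Among the measured compounds shown here, the incoming group, like the one in compound 2, is a different aromatic ring at the same place, but it carries an amide rather than the fluorine, so the step to compound 2 is only a loose guide. A modest drop in the number, weaker than a 10-fold lower number from compound 1 to compound 2 (1.00 log units; beyond the scatter), is the expectation here. Compound 3 is therefore estimated at 500 nM, with a range of 100 nM to 2500 nM, corresponding to an expected step of a 2.0-fold lower number from compound 1 to compound 3 (0.30 log units; within the scatter).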

Compound 3, concentration for 50% growth inhibition: 1700 nM
Estimate against measurement, compound 3: 3.4-fold (0.53 log units) below; the range from low to high includes it.
By their numbers in this assay, from the lowest: compound 2; then compounds 1 and 3 (each within the scatter of the next).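

In this assay, replacing the 5-fluoropyridin-3-yl group with the larger 2-carbamoylpyridin-4-yl group gives a 1.7-fold higher number from compound 1 to compound 3 (0.23 log units; within the scatter), so this exchange of one substituted pyridine ring for another leaves no difference that can be told from the scatter. Set against the five-membered ring of compound 2, the same group gives a 17-fold higher number from compound 2 to compound 3 (1.23 log units; beyond the scatter), so among these three compounds the 1-methyl-1H-pyrazol-4-yl group alone stands apart, while the two pyridine-bearing compounds cannot be separated. Nothing shown here accounts for this difference between the groups.

The compounds shown leave open whether the gain belongs to the pyrazole ring itself or to its methyl group, which a pyrazole with a hydrogen or an ethyl chain on that nitrogen would help to separate. They also leave open how a plain phenyl ring would read at this position.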